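The source may report more compounds than this note shows. Statements on the series, on what has been measured and on what is new or still open speak of the compounds shown alone.

Going by the values given here, compound 2, `CCCN(CC[C@H]1CC[C@H](NS(=O)(=O)c2cccc(C)c2)CC1)[C@H]1CCc2nc(N)sc2C1`, gives 0.89 nM in an assay on brain for displacement of a labelled ligand from D(3) dopamine receptor (Rattus norvegicus) (on this read-out higher numbers stand for weaker inhibition and lower numbers for stronger inhibition), and stands at the lowest of the two numbers measured so far; the nearest is compound 1, `CCCN(CC[C@H]1CC[C@H](NS(=O)(=O)c2cccc3ccccc23)CC1)[C@H]1CCc2nc(N)sc2C1`, which gives 1.5 nM in this assay. Among the compounds with values here, the only measured step, a 1.7-fold lower number from compound 1 to compound 2 (0.23 log units; within the scatter), changed the group on the sulfonyl sulfur, and the present step changes the same position. Compound 3, `CCCN(CC[C@H]1CC[C@H](NS(=O)(=O)c2ccc(C(C)(C)C)cc2)CC1)[C@H]1CCc2nc(N)sc2C1`, differs from compound 2 in one place: 4-(tert-butyl)phenyl in place of 3-methylphenyl on a sulfonyl sulfur. The earlier exchange of aryl groups at this sulfur bears directly on the new one, and because the step of a 1.7-fold lower number from compound 1 to compound 2 (0.23 log units; within the scatter) stayed within the scatter, no movement beyond the scatter is expected in this assay either, with a slight lean towards a higher number. Compound 3 is therefore expected to give 1.3 nM in this assay, with a range from 0.4 nM to 4 nM. The estimated step of a 1.5-fold higher number from compound 2 to compound 3 (0.16 log units; within the scatter) is expected to sit within the scatter.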

Compound 3, inhibition constant: 5 nM
For compound 3 the middle estimate is 3.8-fold (0.59 log units) below the measured one, and the stated range ends below it.
By their numbers in this assay, from the lowest: compounds 2 and 1 (each within the scatter of the next); then compound 3.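

Aryl groups on the sulfonyl sulfur are not interchangeable in this assay: 4-(tert-butyl)phenyl in place of 3-methylphenyl gives a 5.6-fold higher number from compound 2 to compound 3 (0.75 log units; beyond the scatter) and in place of naphthalen-1-yl gives a 3.3-fold higher number from compound 1 to compound 3 (0.52 log units; beyond the scatter), both beyond the scatter, whereas the step between the other two groups stayed within it. Among these three compounds, the group with the most heavy atoms, 4-(tert-butyl)phenyl, therefore stands apart, while the change remains modest and compound 3 still gives 5 nM in this series. No measurement available here accounts for the shift.

Going by these compounds, it remains open whether 4-methylphenyl or 3-(tert-butyl)phenyl on the sulfonyl sulfur would read with compound 2 or with compound 3, which would separate the size of the alkyl group from where it stands on the ring. On these data alone, how a plain phenyl, or a phenyl carrying an amine or a carboxylic acid, would behave at this sulfur is also open.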